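A few compounds are considered here, and "the series" means these few. Any claim that something is new, unique, unknown or untested is made for them only; others in the source may bear on it.

Compound 3, `CCC1(OC(=O)N2CCC(Oc3ncnc(Oc4ccc(S(C)(=O)=O)nc4C)c3F)CC2)CC1`, gives 83% in a functional assay on isolated protein for inhibition of Glucose-dependent insulinotropic receptor (Rattus norvegicus), read by HTRF and cAMP accumulation; a lower number here means a smaller maximal response, a higher number a larger maximal response. Its two companions share the same core and differ from it only on an oxygen next to a carbonyl group: compound 1, `Cc1nc(S(C)(=O)=O)ccc1Oc1ncnc(OC2CCN(C(=O)OC(C)(C)C(F)(F)F)CC2)c1F`, gives 79% in this assay, and compound 2, `Cc1nc(S(C)(=O)=O)ccc1Oc1ncnc(OC2CCN(C(=O)O[C@H](C)C(F)(F)F)CC2)c1F`, gives 85%. The three numbers lie close together: a number 6 percentage points higher from compound 1 to compound 2 (within the scatter), a number 4 percentage points higher from compound 1 to compound 3 (within the scatter) and a number 2 percentage points lower from compound 2 to compound 3 (within the scatter), so compound 3 sits among numbers that the scatter does not separate.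

Compound 4, `Cc1nc(S(C)(=O)=O)ccc1Oc1ncnc(OC2CCN(C(=O)c3ncc(Cl)cn3)CC2)c1F`, is a different kind of change: a group of 7 heavy atoms (4 carbon, 2 nitrogen, 1 chlorine; one six-membered aromatic ring with 2 hetero atoms) in place of a group of 6 heavy atoms (5 carbon, 1 oxygen; one three-membered non-aromatic ring of carbon only), on a carbonyl carbon. Going by the values given here, no measured step exchanges the whole group on the carbonyl carbon in this way; the measured steps only swap one group for another on an oxygen next to a carbonyl group, and each of them stayed within the scatter. What the data show is that the largest response reached in this assay was little moved by those exchanges, and that every measured compound sits in the same band.

On that basis, the step from compound 3 to compound 4 is expected to be a number 1 percentage points lower from compound 3 to compound 4 (within the scatter), with no direction favoured beyond the scatter. Among the compounds with values here, for compound 4 the estimate in this assay is 82%, within a range from 62% to 100%, the width reflecting that the change has no measured counterpart here.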

Compound 4, largest response reached (reported as efficacy), in percent of the reference or control that the assay uses: 77%
Beside the measured number, compound 4's estimate is 5 percentage points above it; low and high end bracket the measured number.
By their numbers in this assay, from the lowest: compounds 4, 1, 3 and 2 (each within the scatter of the next).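

Until now, the steps had only swapped one group for another on the oxygen, whereas compound 4 replaces the whole oxygen-linked group on the carbonyl carbon with 5-chloropyrimidin-2-yl. Even this larger exchange leaves the largest response in this assay in the same band, with a number 6 percentage points lower from compound 3 to compound 4 (within the scatter) and a number 8 percentage points lower from compound 2 to compound 4 (within the scatter) and a number 2 percentage points lower from compound 1 to compound 4 (within the scatter) all printed as inside the usual variation. Among these four compounds, then, a response of this size does not require an oxygen-linked group on this carbonyl carbon, and it is also reached with an aromatic ring with 2 hetero atoms in that place; nothing available explains why the values stay so close together.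

The compounds shown leave open how the response changes when the chlorine of the pyrimidine gives way to a nitrile or a methoxy group, or when a dialkylamine or a longer alkyl chain stands on the carbonyl carbon. They also leave open whether a group carrying a carboxylic acid in this place would still stay in the same band.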